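A few compounds are considered here, and "the series" means these few. Any claim that something is new, unique, unknown or untested is made for them only; others in the source may bear on it.

In a functional assay on LoVo cells (Homo sapiens) for inhibition, read by MTT assay, with a stated time of 24 h (on this read-out higher numbers stand for weaker inhibition and lower numbers for stronger inhibition), two compounds sharing one core have been measured so far. Compound 1 `CC1(C)[C@H]2CC[C@]1(C)N(Cc1cn(-c3cccc(Cl)c3)nn1)C(=O)C2` gives 70 nM, and compound 2 `CC1(C)[C@H]2CC[C@]1(C)N(Cc1cn(-c3cccc(O)c3)nn1)C(=O)C2` gives 410 nM, the higher of the two numbers and therefore the weaker inhibition. The step between them, a 5.9-fold higher number from compound 1 to compound 2 (0.77 log units; beyond the scatter), is modest but beyond the scatter, and it corresponds to hydroxy in place of chloro on an aromatic carbon.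

Compound 3 `COc1ccc(-n2cc(CN3C(=O)C[C@@H]4CC[C@@]3(C)C4(C)C)nn2)cc1` has not yet been measured. It carries 4-methoxyphenyl in place of 3-hydroxyphenyl on an aromatic nitrogen. Among the compounds with values here, only that one measured step bears on this change, and only loosely, since no measured compound carries 4-methoxyphenyl. It does show that compound 1, which has no hydroxy group, gives 70 nM. A modest move toward a lower number is therefore expected in this assay, smaller than the measured 5.9-fold higher number from compound 1 to compound 2 (0.77 log units; beyond the scatter). The estimated step is a 2.1-fold lower number from compound 2 to compound 3 (0.31 log units; beyond the scatter). For compound 3 the estimated value is 200 nM, with an expected range of 60 nM to 700 nM.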

Compound 3, half-maximal inhibitory concentration: 70 nM
For compound 3 the middle estimate is 2.9-fold (0.46 log units) above the measured one, and the stated range covers the measured number.
By their numbers in this assay, from the lowest: compounds 1 and 3 (each within the scatter of the next); then compound 2.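

In this assay, 4-methoxyphenyl in place of 3-hydroxyphenyl on an aromatic nitrogen gives a 5.9-fold lower number from compound 2 to compound 3 (0.77 log units; beyond the scatter), while 4-methoxyphenyl in place of 3-chlorophenyl at the same place gives no change at the digits printed from compound 1 to compound 3 (within the scatter). The earlier pair could not show whether the gap between them reflected something particular to the 3-chlorophenyl group or to the 3-hydroxyphenyl group, but now two different groups at this place cannot be told apart, and compound 2, whose 3-hydroxyphenyl group is the only one of the three carrying a hydrogen-bond donor, stands alone at the higher number. No measurement presented here explains why compound 2 separates from the other two compounds, so this remains an observation across three compounds only.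

The compounds shown leave open whether the hydroxy group itself or its place on the phenyl ring matters, since the methoxy and hydroxy groups are not compared at one ring position in this set. They also leave open how a phenyl ring bearing an amine or a carboxylic acid would behave at this place on the shared core.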